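This account rests on a few compounds, and the source may have more. Where it says the series, first, only, none or still open, it means among the compounds named here.

Working notes on the series, read in a functional assay on the whole organism (strain Hartley) for inhibition, with Cavia porcellus as the target, with stated times of 15 min and 2 min; on this read-out higher numbers stand for an effect only at larger amounts of compound and lower numbers for an effect already at smaller amounts. Compound 1 `CCCCC1([C@@H](O)/C=C/C2CCC(=O)[C@@H]2CCCCCCC(=O)O)CCC1` gives 0.0203 mg/kg, compound 3 `CCCCC1([C@H](O)/C=C/C2CCC(=O)[C@@H]2C/C=C\CCCC(=O)O)CCC1` gives 0.00767 mg/kg, and compound 2 `CCCCC1([C@H](O)/C=C/C2[C@H](O)CC(=O)[C@@H]2C/C=C\CCCC(=O)O)CCC1` gives 0.00251 mg/kg, the lowest of the three numbers. Compound 2 therefore shows its effect at the smallest amount so far.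

Compound 4 `CCCC1([C@H](O)/C=C/C2[C@H](O)CC(=O)[C@@H]2C/C=C\CCCC(=O)O)CCC1` departs from compound 2 at one place: hydrogen in place of methyl on a saturated chain carbon, three bonds along the chain from a saturated ring carbon. This is hydrogen in place of methyl on a saturated chain carbon, three bonds along the chain from a saturated ring carbon, which reads as butyl to propyl.

Within the data shown here, no measured step touches this chain. The only one available is a 3.1-fold higher number from compound 2 to compound 3 (0.49 log units; beyond the scatter), which lies at another place in the molecule and so offers a scale, not a precedent. A modest step is expected in this assay, towards a higher number, although the direction has no direct support in the data. The expected step is a 2.0-fold higher number from compound 2 to compound 4 (0.30 log units; within the scatter). For compound 4 the estimate is 0.005 mg/kg, with an expected range of 0.0015 mg/kg to 0.017 mg/kg.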

Compound 4, dose for half-maximal effect: 0.003 mg/kg
Compound 4: middle estimate off by 1.7-fold (0.22 log units), on the high side, and the stated range covers the measured number.
By their numbers in this assay, from the lowest: compounds 2 and 4 (each within the scatter of the next); then compound 3; then compound 1.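

In this assay, among these compounds, the first measured step at this chain, butyl to propyl, is a 1.2-fold higher number from compound 2 to compound 4 (0.08 log units; within the scatter), so on this read-out compound 4 cannot be told apart from compound 2. At this place the methyl at the chain end can therefore give way to hydrogen without a step beyond the scatter, whereas a 3.1-fold higher number from compound 2 to compound 3 (0.49 log units; beyond the scatter), at the saturated ring carbon, lies beyond it. Nothing available bears on what lies behind this result.

The compounds shown leave open whether a shorter ethyl chain or a longer pentyl chain at this place would also stay within the scatter of compound 2. Also open, as far as these compounds go, is whether butyl to propyl reads the same way on the core of compound 3, which carries hydrogen in place of the hydroxy.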